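Two compounds at the limit, and a new sulfur group

The compounds below may be only part of what the source reports. "The series", "measured", "known", "first", "only" and "open" are said of these compounds alone.

In a functional assay on DU-145 cells (Homo sapiens) for inhibition, read by trypan blue exclusion, with a stated time of 96 h (a higher number here means a weaker inhibitor of growth, a lower number a stronger inhibitor of growth), compound 1 `Cc1ccc(S/C(=C/c2ccc(N(C)C)cc2)C(=O)c2ccc(Cl)cc2)cc1` gives > 100000 nM, which is a limit of the assay and not a number. Compound 2 `Cc1ccc(S(=O)(=O)/C(=C/c2ccc(N(C)C)cc2)C(=O)c2ccc(Cl)cc2)cc1` gives > 100000 nM, which is also a limit. Compound 2 therefore has no number of its own and stands with compound 1 at the limit of > 100000 nM in this assay, at which 2 of the 2 values shown sit.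

Compound 3 `CN(C)c1ccc(/C=C(/SCc2ccc(Cl)cc2)C(=O)c2ccc(Cl)cc2)cc1` has (4-chlorobenzyl)sulfanyl in place of (4-methylphenyl)sulfonyl on a double-bonded chain carbon bound to a carbonyl carbon and a double-bonded chain carbon. The core is otherwise unchanged.

Within the data shown here, the only measured step at this place is a step that the two limits leave unreadable from compound 1 to compound 2. It offers no size to carry over, and neither compound shows a measured level of growth inhibition to start from. The expectation for this assay is therefore cautious: little change, and quite possibly another limit. The expected change is an at least 1.2-fold lower number from compound 2 to compound 3 (0.09 log units; that floor lies within the scatter), and this estimate is only loosely supported. For compound 3, the estimated value is 80000 nM, with an expected range from 15000 nM to 200000 nM.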

Compound 3, concentration for 50% growth inhibition: > 100000 nM
Compound 3 gave a limit, no number (the forecaster's own chance of this, stated with the estimate: 65%); middle value at least 1.2-fold (0.09 log units) away from the limit.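

Compound 3 joins compound 1 and compound 2 at a limit of the assay and not a number, so neither new step to compound 3 can be read: the limit of > 100000 nM in this assay, at which 3 of the 3 values shown sit.

The compounds shown leave open whether any group at this place on the shared core gives a measurable value in this assay.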